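Series notes: from methoxy to chloro

The source may hold more compounds than are shown below. What is called first, only, known or untested is meant among the compounds shown, and "the series" means these compounds.

Measured in a functional assay on HepG2 cells (Homo sapiens) for inhibition, read by MTT assay, with a stated time of 72 h; a lower number here means a stronger inhibitor, a higher number a weaker inhibitor:
- compound 1 `O=C(Nc1ccccc1)C1CCN(C/C=C/c2ccccc2)CC1` gives 90900 nM
- compound 2 `Cc1ccc(NC(=O)C2CCN(C/C=C/c3ccccc3)CC2)cc1` gives 33900 nM
- compound 3 `COc1cccc(NC(=O)C2CCN(C/C=C/c3ccccc3)CC2)c1` gives 78600 nM

Two steps place compound 3 at the high end of these numbers: a 1.2-fold lower number from compound 1 to compound 3 (0.06 log units; within the scatter), and a 2.3-fold higher number from compound 2 to compound 3 (0.37 log units; beyond the scatter). Compound 4 `O=C(Nc1cccc(Cl)c1)C1CCN(C/C=C/c2ccccc2)CC1` has chloro in place of methoxy on an aromatic carbon. For the measured compounds named here, no chloro compound has been measured, so the nearest guides are the two other substitutions on an aromatic carbon. Methoxy gave a 1.2-fold lower number from compound 1 to compound 3 (0.06 log units; within the scatter), while methyl gave a 2.7-fold lower number from compound 1 to compound 2 (0.43 log units; beyond the scatter). Only a small change in this assay is therefore expected, leaning toward a lower number. The expected step is a 1.4-fold lower number from compound 3 to compound 4 (0.16 log units; within the scatter). For compound 4 the estimated value is 55000 nM, with an expected range of 22000 nM to 120000 nM.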

Compound 4, half-maximal inhibitory concentration: 20000 nM
Beside the measured number, compound 4's estimate is 2.8-fold (0.44 log units) above it; measured number outside the range, below it.
By their numbers in this assay, from the lowest: compounds 4 and 2 (each within the scatter of the next); then compounds 3 and 1 (each within the scatter of the next).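

In this assay, this aromatic carbon, meta to a large group, now shows a clear response to its substituent: chloro gives a 4.5-fold lower number from compound 1 to compound 4 (0.66 log units; beyond the scatter) in place of hydrogen and a 3.9-fold lower number from compound 3 to compound 4 (0.59 log units; beyond the scatter) in place of methoxy, whereas methoxy had stayed within the scatter of hydrogen. The 3-chlorophenyl group in place of 4-methylphenyl gives a 1.7-fold lower number from compound 2 to compound 4 (0.23 log units; within the scatter) in this assay, so these two substituted compounds cannot be separated. Nothing available accounts for the difference between chloro and methoxy. Still open, from the compounds shown here alone, is how an amine or a carboxylic acid on this same aromatic carbon would read. Going by these compounds, whether bromo would track chloro is also open.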